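The source may report more compounds than this note shows. Statements on the series, on what has been measured and on what is new or still open speak of the compounds shown alone.

Three measured compounds and one unmeasured compound are compared in a functional assay on HeLa cells (Homo sapiens) for cytotoxicity, read by MTT assay, with a stated time of 2 days, tested at 1 uM; on this read-out lower numbers stand for a stronger effect and higher numbers for a weaker effect at the one concentration tested. Compound 1, `COc1ccc(-c2cc3cc(-c4ccccc4)cc(C(C)=O)c3[nH]2)cc1`, gives 61.5% in this assay. Compound 2, `COc1ccc(-c2cc3cc(-c4ccc(F)cc4)cc(C(C)=O)c3[nH]2)cc1`, differs from compound 1 only by fluoro in place of hydrogen on an aromatic carbon, and in this assay compound 2 gives 62.9%. That single change produced a number 1.4 percentage points higher from compound 1 to compound 2 (within the scatter). Compound 3, `CC(=O)c1cc(/C=C/c2ccccc2)cc2cc(-c3ccc(F)cc3)[nH]c12`, is built on a different core, and the difference between the core of compound 1 and the core of compound 3 is not broken down here. In this assay compound 3 gives 60.5%, a value that sits close to those of compound 1 and compound 2, so all three measured compounds behave much alike here.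

Compound 4, `CC(=O)c1cc(/C=C/c2ccc(F)cc2)cc2cc(-c3ccc(F)cc3)[nH]c12`, has not yet been measured. It differs from compound 3 by fluoro in place of hydrogen on an aromatic carbon, which is the same change that turns compound 1 into compound 2, and in both pairs the change sits in the same place on the ring. Among the compounds shown, this change has been measured only once, so any expectation for compound 4 rests on that one step. That earlier step was small: a number 1.4 percentage points higher from compound 1 to compound 2 (within the scatter). On that basis the step is expected to be a number 1.5 percentage points higher from compound 3 to compound 4 (within the scatter). Compound 4 is therefore estimated to give about 62% in this assay, with a likely range from 53% to 71%.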

Compound 4, a percentage reported as activity, at one concentration (the size of the read-out at that concentration, not a potency): 53.7%
For compound 4 the middle estimate is 8.3 percentage points above the measured one, and the stated range covers the measured number.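

On the core of compound 3, fluoro in place of hydrogen on an aromatic carbon, here turning 2-phenylethenyl into 2-(4-fluorophenyl)ethenyl, gives a number 6.8 percentage points lower from compound 3 to compound 4 (within the scatter) in this assay, so this step is no larger than the differences commonly seen between repeated measurements. Set beside the earlier step, the result on one core cannot be told apart from the result on the other: the same change on two cores in this assay, a number 1.4 percentage points higher (within the scatter) from compound 1 to compound 2 and a number 6.8 percentage points lower (within the scatter) from compound 3 to compound 4, 8.2 percentage points apart, within the scatter of two such steps This shows that the change has not produced an effect beyond the scatter on either core, and that this read-out gives no sign of the two cores responding differently; it does not show that the change has no effect at all or that it acts identically on both cores, as the comparison rests on only two pairs at one concentration.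

The compounds shown hold only hydrogen or fluoro at this place on the ring, so what an amine or a carboxylic acid there would do in this assay remains open. Also open, going by these compounds, is how the same change would read at other concentrations, as a number from a single concentration is not a measure of potency.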